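Indolyl pyran series: phenyl replacing naphthalen-1-yl at compound 2

A few compounds are considered here, and "the series" means these few. Any claim that something is new, unique, unknown or untested is made for them only; others in the source may bear on it.

Measured so far in a functional assay, tested at 400 ug/mL; on this read-out higher numbers stand for a stronger effect at the one concentration tested and lower numbers for a weaker effect:
compound 1, `Cc1ccccc1C1C(C#N)=C(N)OC(c2c[nH]c3ccccc23)=C1C#N`, gives 25.7%
compound 2, `N#CC1=C(N)OC(c2c[nH]c3ccccc23)=C(C#N)C1c1cccc2ccccc12`, gives 10.4%

Compound 2 is the lower of the two numbers in this assay; its nearest neighbour is compound 1, separated by a number 15.3 percentage points lower from compound 1 to compound 2 (beyond the scatter). Compound 3, `N#CC1=C(N)OC(c2c[nH]c3ccccc23)=C(C#N)C1c1ccccc1`, is not yet measured. It differs from compound 2 by phenyl in place of naphthalen-1-yl on a saturated ring carbon. Among the compounds with values here, the one measured step that touches the same saturated ring carbon is a number 15.3 percentage points lower from compound 1 to compound 2 (beyond the scatter), a modest drop when a 2-methylphenyl group was exchanged for naphthalen-1-yl. Within the data shown here, compound 3 carries the smaller phenyl group there, so going back toward the range of compound 1 seems the most plausible outcome, though only one step is available to lean on. For compound 3 the expected step is a number 9.6 percentage points higher from compound 2 to compound 3 (within the scatter), a modest rise in this assay. The estimate for compound 3 in this assay is therefore 20%, with a range from 6% to 34%.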

Compound 3, a percentage reported as activity, at one concentration (the size of the read-out at that concentration, not a potency): 26.7%
Compound 3: middle estimate off by 6.7 percentage points, on the low side, within the range that was stated.
By their numbers in this assay, from the lowest: compound 2; then compounds 1 and 3 (each within the scatter of the next).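

In this assay, the step from two aromatic rings to one on the saturated ring carbon is a number 16.3 percentage points higher from compound 2 to compound 3 (beyond the scatter), so the low number of compound 2 does not depend on comparison with the 2-methylphenyl group alone. The methyl on the aromatic carbon has no readable effect, the step being a number 1 percentage points higher from compound 1 to compound 3 (within the scatter), and among these three compounds only naphthalen-1-yl stands apart from the other two. Nothing available explains this separation.

Still open, from the compounds shown here alone, is whether a phenyl group carrying a chlorine or a methoxy group, or an amine or a carboxylic acid at this saturated ring carbon, would stay with compound 1 and compound 3 or fall toward compound 2. With one concentration per compound, these numbers also give no potency for any of the three.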